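Removing One Methoxy Group: What the Earlier Pair Suggests

The source may hold more compounds than are shown below. What is called first, only, known or untested is meant among the compounds shown, and "the series" means these compounds.

compound 1 `COc1cc(-c2cc(/C=C/C(=O)c3ccc(N)cc3)[nH]n2)cc(OC)c1OC`: -65%
compound 2 `COc1ccc(-c2cc(/C=C/C(=O)c3ccc(N)cc3)[nH]n2)cc1OC`: -73%
compound 3 `COc1cc(C(=O)/C=C/c2cc(-c3cc(OC)c(OC)c(OC)c3)n[nH]2)cc(OC)c1OC`: -91%

All three numbers come from a functional assay on MDA-MB-468 cells (Homo sapiens) for cytotoxicity, read by sulforhodamine B assay, with a stated time of 48 h, tested at 100 uM; on this read-out higher numbers stand for a weaker effect at the one concentration tested and lower numbers for a stronger effect. Compound 1 and compound 2 differ in one place only: hydrogen in place of methoxy on an aromatic carbon. The result of that change was a number 8 percentage points lower from compound 1 to compound 2 (within the scatter), so the two values cannot be told apart with confidence. Compound 3 gives the lowest number of the three, and its distance from both compound 1 and compound 2 lies beyond the scatter; the difference between the core of compound 3 and the core of compound 1 is not broken down here.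

Compound 4 `COc1ccc(-c2cc(/C=C/C(=O)c3cc(OC)c(OC)c(OC)c3)[nH]n2)cc1OC` has not yet been measured. It differs from compound 3 by the same change that turned compound 1 into compound 2: hydrogen in place of methoxy on an aromatic carbon. The step expected from compound 3 to compound 4 is a number 2 percentage points lower from compound 3 to compound 4 (within the scatter), because a number 8 percentage points lower from compound 1 to compound 2 (within the scatter) is the only earlier outcome of this change, and that one stayed within the scatter. A small shift on top of the already low number of compound 3 is therefore expected. Compound 4 is estimated to give -93%, with a likely range from -100% to -82%.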

Compound 4, a percentage reported as activity, at one concentration (the size of the read-out at that concentration, not a potency): -58%
Estimate against measurement, compound 4: 35 percentage points below; measured number outside the range, above it.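

In this assay, putting hydrogen in place of methoxy on an aromatic carbon gave a number 33 percentage points higher from compound 3 to compound 4 (beyond the scatter), which means a weaker effect at the one concentration tested. Set beside the earlier case, the same change did not give the same outcome on the two cores: the same change on two cores in this assay, a number 8 percentage points lower (within the scatter) from compound 1 to compound 2 and a number 33 percentage points higher (beyond the scatter) from compound 3 to compound 4, 41 percentage points apart, beyond the scatter of two such steps This shows that the result of this change on the core of compound 1 could not be carried over to the core of compound 3, but it does not show why the two cores respond differently, and two pairs are too few to give a rule for any other core in this series.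

The compounds shown leave open how a hydroxyl group or a fluorine atom in place of the same methoxy would behave on either core. From the compounds shown here alone, each number also comes from a single concentration and tells only how strong or weak the effect is at that concentration; how the effect would change at other concentrations remains open.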